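Shortening the side chain from butyl to propyl

The source may report more compounds than this note shows. Statements on the series, on what has been measured and on what is new or still open speak of the compounds shown alone.

Compound 2 `CCCCCCCOc1ccc(CCC(N)(CO)CCCC)cc1` was tested in a functional assay on the whole organism (Popliteal lymph node) with Rattus norvegicus as the target; a lower number here means that less compound is needed, a higher number that more compound is needed for the effect. Compound 2 reaches only a limit there, > 10 mg/kg. Compound 1 `CCCCCCCCc1ccc(CCC(N)CO)cc1` also reaches only a limit, > 10 mg/kg. Both therefore sit at the limit of > 10 mg/kg in this assay, at which 2 of the 3 values shown sit. Going by the values given here, compound 3 `CCCCCCCOc1ccc(CCC(N)(CO)C(C)C)cc1`, by contrast, gives a real number, 2.7 mg/kg, and the one measured step, an at least 3.7-fold lower number from compound 2 to compound 3 (0.56 log units; beyond the scatter), is the only guide available. Compound 4 `CCCCCCCOc1ccc(CC[C@](N)(CO)CCC)cc1` differs from compound 2 in one place: a group of 7 heavy atoms (5 carbon, 1 nitrogen, 1 oxygen; no ring) in place of a group of 8 heavy atoms (6 carbon, 1 nitrogen, 1 oxygen; no ring), on a saturated chain carbon, two bonds along the chain from an aromatic carbon. This change goes in the same direction as the one to isopropyl, but without the branching, so only part of that step is expected to carry over, because an at least 3.7-fold lower number from compound 2 to compound 3 (0.56 log units; beyond the scatter) came with branching. Compound 4 is expected to give about 5 mg/kg, between 2 mg/kg and 15 mg/kg, which would mean an at least 2.0-fold lower number from compound 2 to compound 4 (0.30 log units; that floor lies within the scatter).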

Compound 4, dose for 50% inhibition: > 10 mg/kg
Compound 4: no number, only a limit; the forecaster's own chance of this, stated with the estimate: 40%; middle value at least 2.0-fold (0.30 log units) away from the limit.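

Compound 4 gives only a limit in this assay, > 10 mg/kg. Its step from compound 2 cannot be read, as both values are limits, and it joins the other compounds there: the limit of > 10 mg/kg in this assay, at which 3 of the 4 values shown sit. Unbranched propyl falls short of isopropyl, with an at least 3.7-fold higher number from compound 3 to compound 4 (0.56 log units; beyond the scatter), so shortening the butyl chain by itself does not give a real number, and of the side chains shown in this place only the branched isopropyl of compound 3 does. Still open, as far as these compounds go, is whether ethyl or cyclopropyl in this place would give a real number, and whether the mirror-image form of compound 4 would differ.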